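The source may hold more compounds than are shown below. What is called first, only, known or untested is meant among the compounds shown, and "the series" means these compounds.

Series notes. Compound 1 `O=C(O)c1c(Cn2c(=O)n(C3CC3)c3ccncc32)nc2cc(Cl)ccn12` and compound 2 `NC(=O)CCc1c(Cn2c(=O)n(C3CC3)c3ccncc32)nc2cc(Cl)ccn12` share one core; compound 2 carries 2-carbamoylethyl in place of carboxy on an aromatic carbon. In an ADME assay on HEp-2 cells (Homo sapiens) for cytotoxicity, read by CCK-8 assay, with a stated time of 6 days (a higher number here means that more compound is tolerated, a lower number that less compound is tolerated), compound 1 gives > 100000 nM, which is a limit of the assay and not a number. In this assay compound 2 likewise gives > 100000 nM, again only a limit. The step that the two limits leave unreadable from compound 1 to compound 2 cannot be read, because both ends sit at the limit of > 100000 nM in this assay, at which 2 of the 2 values shown sit. For the measured compounds named here, compound 2 thus stands at the limit with no number of its own, and the one other value shown is also a limit.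

Compound 3 `CS(=O)(=O)NC(=O)CCc1c(Cn2c(=O)n(C3CC3)c3ccncc32)nc2cc(Cl)ccn12` differs from compound 2 by methylsulfonyl in place of hydrogen on an amide-type nitrogen. Going by the values given here, no measured step bears on this change: the only measured step, from compound 1 to compound 2, was unreadable, and no compound has a number in this assay. In this assay the expected step is a number no higher from compound 2 to compound 3 (the limit leaves the size open), none beyond the scatter. Compound 3 is therefore estimated at 100000 nM, with a range from 40000 nM to 300000 nM, and most probably reported again only as a limit.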

Compound 3, half-maximal cytotoxic concentration: > 100000 nM
Compound 3: only a limit was reported (the forecaster's own chance of this, stated with the estimate: 85%); the middle value sits exactly at the limit.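

No step among compound 1, compound 2 and compound 3 can be read in this assay, because all three end at the same limit: the limit of > 100000 nM in this assay, at which 3 of the 3 values shown sit.

The compounds shown leave open whether methylsulfonyl in place of hydrogen on an amide-type nitrogen changes the tolerated concentration at all: none of them has a number of its own in this assay.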